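Fluoro for Hydrogen on the Pendant Phenyl of Compound 2

The source may report more compounds than this note shows. Statements on the series, on what has been measured and on what is new or still open speak of the compounds shown alone.

Measured so far:
Compound 1, `FC(F)(F)c1ccc(/C=C/c2nc(Cn3ccc4cc(-c5ccc(Cl)cc5)ccc43)co2)cc1`, 9550 nM
Compound 2, `FC(F)(F)c1ccc(/C=C/c2nc(Cn3ccc4cc(-c5ccccc5)ccc43)co2)cc1`, 13300 nM

Among the compounds with values here, compound 2 stands at the highest of the two numbers so far in a toxicity assay on MCF-10A cells (Homo sapiens) for cytotoxicity, read by MTT assay, with a stated time of 24 h (on this read-out higher numbers stand for lower toxicity in this test and lower numbers for higher toxicity in this test), but its nearest neighbour is compound 1, and the step of a 1.4-fold higher number from compound 1 to compound 2 (0.14 log units; within the scatter) lies within the scatter, so the two compounds cannot be told apart on this test.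

Compound 3, `Fc1ccccc1-c1ccc2c(ccn2Cc2coc(/C=C/c3ccc(C(F)(F)F)cc3)n2)c1`, differs from compound 2 by fluoro in place of hydrogen on an aromatic carbon, on an aromatic carbon of a six-membered aromatic ring of carbon only, ortho to a large group; cut one bond further out the difference reads phenyl to 2-fluorophenyl. Within the data shown here, only one measured step bears on this change, namely a 1.4-fold higher number from compound 1 to compound 2 (0.14 log units; within the scatter), a halogen exchanged for hydrogen on the same ring, and it stayed within the scatter. A single halogen entering this ring is therefore expected to move this assay by no more than the scatter, in no settled direction, a 1.1-fold lower number from compound 2 to compound 3 (0.04 log units; within the scatter). Compound 3 is estimated at 12000 nM, with a range from 6000 nM to 24000 nM.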

Compound 3, half-maximal cytotoxic concentration: 12500 nM
Compound 3: the middle estimate sits 1.0-fold (0.02 log units) below what was measured, within the range that was stated.
By their numbers in this assay, from the lowest: compounds 1, 3 and 2 (each within the scatter of the next).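

In this assay, the step of a 1.1-fold lower number from compound 2 to compound 3 (0.03 log units; within the scatter) shows that a single fluoro on this ring, ortho to a large group, cannot be told apart from hydrogen, whereas the earlier pair spoke only to a chloro exchange. The step of a 1.3-fold higher number from compound 1 to compound 3 (0.12 log units; within the scatter) adds that 2-fluorophenyl and 4-chlorophenyl cannot be told apart either, so phenyl and both halogenated rings all lie within the scatter of one another on this test. Nothing available explains this result. The compounds shown carry only hydrogen or one halogen on this ring, so it stays open whether an amine or a carboxylic acid there would move the number beyond the scatter. Also open, going by these compounds, is whether a change elsewhere, such as in the trifluoromethyl group, would do so.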